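This account rests on a few compounds, and the source may have more. Where it says the series, first, only, none or still open, it means among the compounds named here.

Three compounds have been measured in a functional assay on BGC-823 cells (Homo sapiens) for inhibition, read by CCK-8 assay, with a stated time of 48 h; on this read-out lower numbers stand for stronger inhibition and higher numbers for weaker inhibition:

Compound 1, `Cc1ccc(C2=NN(C3=NC(=O)CS3)C(c3ccc4ccccc4c3)C2)cc1`: 7790 nM
Compound 2, `Brc1ccc(C2=NN(C3=NC(c4ccccc4)CS3)C(c3ccc4ccccc4c3)C2)cc1`: 13000 nM
Compound 3, `Cc1ccc(C2=NN(C3=NC(c4ccccc4)CS3)C(c3ccc4ccccc4c3)C2)cc1`: 8940 nM

Compound 3 gives the second highest of these three numbers. Its nearest neighbour is compound 1: a 1.1-fold higher number from compound 1 to compound 3 (0.06 log units; within the scatter). Compound 2 lies furthest away: a 1.5-fold lower number from compound 2 to compound 3 (0.16 log units; within the scatter). Both steps stay within the scatter, so on these numbers the three compounds cannot be told apart.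

Compound 4, `Cc1ccc(C2=NN(C3=NC(c4ccccc4)CS3)C(c3cccc4ccccc34)C2)cc1`, has not yet been measured. Compared with compound 3 the change is naphthalen-1-yl in place of naphthalen-2-yl on a saturated ring carbon. The two compounds contain the same atoms, joined differently, and the change sits on a saturated ring carbon of the shared core.

Neither measured step touches this position: one exchanges a group on the ring nitrogen, the other a group on an aromatic carbon. Among the measured compounds shown here, no step in the set therefore bears directly on the move from naphthalen-2-yl to naphthalen-1-yl. What the measured steps do show is that both were small, within the scatter, but that says nothing certain about this change. The expected step is none beyond the scatter, and a 1.0-fold higher number from compound 3 to compound 4 (0.00 log units; within the scatter) is the estimate. Compound 4 is estimated at 9000 nM, with a range from 3000 nM to 27000 nM.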

Compound 4, half-maximal inhibitory concentration: 13300 nM
Estimate against measurement, compound 4: 1.5-fold (0.17 log units) below; the range from low to high includes it.
By their numbers in this assay, from the lowest: compounds 1, 3, 2 and 4 (each within the scatter of the next).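

Among the compounds shown here, compound 4 gives the first reading at this position, the saturated ring carbon next to the ring nitrogen, where the earlier steps changed other parts of the molecule. In this assay, putting naphthalen-1-yl in place of naphthalen-2-yl gives a 1.5-fold higher number from compound 3 to compound 4 (0.17 log units; within the scatter), so the two compounds cannot be told apart even though their atoms are joined differently. With the rest of compound 3 held constant, these numbers therefore show no measurable preference between these two attachments of the same group, and nothing shown here gives any explanation for the size of the step.

Still open, from the compounds shown here alone, is whether a different kind of group on this carbon, such as a plain phenyl ring, a pyridine ring or a phenyl ring carrying a carboxylic acid, would move the number beyond the scatter. Going by these compounds, it is also open whether naphthalen-1-yl would behave in the same way alongside the bromo group of compound 2 or on the ring nitrogen group of compound 1, since this one pair tests the swap in a single setting.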